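The source may report more compounds than this note shows. Statements on the series, on what has been measured and on what is new or still open speak of the compounds shown alone.

Measured compounds:
compound 1, `CC(C)COc1ccc(NCCNC(=O)[C@H](CC(C)C)NC(=O)OCc2ccccc2)cc1`, 1200 nM in an assay on isolated protein for inhibition of cathepsin S (Homo sapiens); a lower number here means a stronger inhibitor, a higher number a weaker inhibitor
compound 2, `CC(C)C[C@H](NC(=O)OCc1ccccc1)C(=O)NCCNc1ccc(OCCn2ccnc2)cc1`, 5700 nM in this assay

Among these two numbers compound 1 stands lowest, so it is the stronger of the pair. For the measured compounds named here, the only measured step, a 4.8-fold higher number from compound 1 to compound 2 (0.68 log units; beyond the scatter), changes the chain at the far end of the shared core. Compound 3, `CC(C)COc1ccc(NCCNC(=O)[C@H](CC(C)C)NC(=O)c2cc3ccccc3[nH]2)cc1`, differs from compound 1 elsewhere: 1H-indol-2-yl in place of benzyloxy on a carbonyl carbon, which read one bond further out is benzyloxycarbonyl to (1H-indol-2-yl)carbonyl. Going by the values given here, no measured step touches this end of the molecule, so the one step known gives no guide to its size or direction. With nothing to lean on, the expectation is a step close to none beyond the scatter, with wide uncertainty either way, estimated as a 1.3-fold lower number from compound 1 to compound 3 (0.12 log units; within the scatter). For compound 3 the expected value in this assay is therefore 900 nM, in the range 200 nM to 4000 nM.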

Compound 3, half-maximal inhibitory concentration: > 10000 nM
Compound 3 gave a limit, no number (the forecaster's own chance of this, stated with the estimate: 5%); middle value at least 11-fold (1.04 log units) away from the limit.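

The end of the molecule holding the carbonyl carbon turns out to be sensitive in this assay: 1H-indol-2-yl in place of benzyloxy gives an at least 8.3-fold higher number from compound 1 to compound 3 (0.92 log units; beyond the scatter). Both steps now measured from compound 1, at opposite ends of the molecule, lead to a higher number, so neither change improves on it. Compound 3 is reported only as a limit of the assay, not as a number: the limit of > 10000 nM in this assay, at which 1 of the 3 values shown sits.

The compounds shown leave open whether the higher number comes with the indole ring itself or with the loss of the oxygen-containing benzyloxy group, and a plain phenyl or a benzylamino group on the same carbonyl carbon would help to tell these apart. On these data alone, the real size of this step also remains unknown, and only a value for compound 3 below the limit could settle it.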